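Replacing the benzyl group of compound 2

A few compounds are considered here, and "the series" means these few. Any claim that something is new, unique, unknown or untested is made for them only; others in the source may bear on it.

Compound 1 `COc1ccc(CN(C(=O)CSC(=S)N2CCN(C(=O)OC(C)(C)C)CC2)c2ccc(Cl)cc2)cc1`: > 20000 nM
Compound 2 `COc1cc(N(Cc2ccc(Cl)cc2)C(=O)CSC(=S)N2CCN(C(=O)OC(C)(C)C)CC2)cc(OC)c1OC`: 12900 nM

Both compounds were tested in a functional assay on MGC-803 cells (Homo sapiens) for inhibition, read by CCK-8 assay, with a stated time of 48 h; a lower number here means a stronger inhibitor, a higher number a weaker inhibitor. For compound 1, the entry > 20000 nM is a limit of the assay and not a number. For the measured compounds named here, compound 2, at 12900 nM, therefore holds the only actual number so far, and no measured step yet connects it to another compound.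

The next compound is compound 3 `COc1ccc(CN(C(=O)CSC(=S)N2CCN(C(=O)OC(C)(C)C)CC2)c2cc(OC)c(OC)c(OC)c2)cc1C`. It has 4-methoxy-3-methylphenyl in place of 4-chlorophenyl on a saturated chain carbon bound to an amide-type nitrogen. Going by the values given here, no measured pair isolates this change. With compound 2 at 12900 nM as the sole anchor, no step beyond the scatter is expected in this assay, in either direction. The expected change is a 1.2-fold lower number from compound 2 to compound 3 (0.07 log units; within the scatter). Compound 3 is estimated at 11000 nM, with an expected range of 4000 nM to 20000 nM.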

Compound 3, half-maximal inhibitory concentration: > 20000 nM
Compound 3: no number, only a limit; the forecaster's own chance of this, stated with the estimate: 25%; middle value at least 1.8-fold (0.25 log units) from the limit.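

Going from 4-chlorobenzyl to 4-methoxy-3-methylbenzyl on a saturated chain carbon bound to an amide-type nitrogen gives the first step readable at this position in this assay, an at least 1.5-fold higher number from compound 2 to compound 3 (0.19 log units; that floor lies within the scatter). Compound 3 gives > 20000 nM, which is a limit of the assay and not a number. The change therefore brings no lower number at this position, but its true size stays unknown and the step is only a floor, because it ends on a limit: the limit of > 20000 nM in this assay, at which 2 of the 3 values shown sit.

The compounds shown leave open whether the methoxy or the methyl of the entering group accounts for the step. They also leave open how an unsubstituted benzyl, a 4-fluorobenzyl or a pyridylmethyl group would read at this position.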